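The source may report more compounds than this note shows. Statements on the series, on what has been measured and on what is new or still open speak of the compounds shown alone.

Measured so far:
compound 1 `COc1cc2c(Oc3c(F)cc(NC(=O)NN4C(=O)CCSC4c4c(F)cccc4F)cc3F)ccnc2cc1OCCCN1CCCC1` — 400 nM
compound 2 `COc1cc2c(Oc3c(F)cc(NC(=O)NN4C(=O)CSC4c4c(F)cccc4F)cc3F)ccnc2cc1OCCCN1CCc2sccc2C1` — > 20000 nM

Compound 2 stands at the edge of what the numbers show: in a functional assay on A549 cells (Homo sapiens) for antiproliferative activity, read by MTT assay, with a stated time of 72 h (on this read-out lower numbers stand for stronger inhibition and higher numbers for weaker inhibition), compound 2 gives > 20000 nM, which is a limit of the assay and not a number, as recorded in the limit of > 20000 nM in this assay, at which 1 of the 2 values shown sits. Compound 1 differs from compound 2 in several places; in this assay compound 1 gives 400 nM, so the two compounds cannot be joined by a single step and their values are only placed side by side.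

Compound 3 `CCN(CC)CCCOc1cc2nccc(Oc3c(F)cc(NC(=O)NN4C(=O)CSC4c4c(F)cccc4F)cc3F)c2cc1OC` is the next compound to be measured in this assay. It differs from compound 2 in one place: a group of 5 heavy atoms (4 carbon, 1 nitrogen; no ring) in place of a group of 9 heavy atoms (7 carbon, 1 nitrogen, 1 sulfur; one five-membered aromatic ring with 1 hetero atom, one six-membered non-aromatic ring with 1 hetero atom), on a saturated chain carbon, three bonds along the chain from an oxygen on an aromatic ring. Within the data shown here, with compound 2 sitting at a limit, no measured step tells how a change at this position moves the read-out, and nothing in the two values fixes the direction. Compound 1, which also carries a small amine on this chain, gives 400 nM, and that is the only anchor for a guess. Compound 3 is therefore expected to land somewhere between that anchor and the limit, with a wide range: the step from compound 2 to compound 3 is estimated at an at least 5.0-fold lower number from compound 2 to compound 3 (0.69 log units; beyond the scatter), and compound 3 is expected to give about 4000 nM, between 800 nM and 20000 nM.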

Compound 3, half-maximal inhibitory concentration: 450 nM
For compound 3 the middle estimate is 8.9-fold (0.95 log units) above the measured one, outside the stated range (below it).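

The position on a saturated chain carbon, three bonds along the chain from an oxygen on an aromatic ring, now has its first readable change in this assay: diethylamino in place of the group with one five-membered aromatic ring and one six-membered non-aromatic ring gives an at least 44-fold lower number from compound 2 to compound 3 (1.64 log units; beyond the scatter). Compound 2 gives > 20000 nM, which is a limit of the assay and not a number. The step therefore fixes a direction and a minimum size for this change, while its full size stays unknown: the limit of > 20000 nM in this assay, at which 1 of the 3 values shown sits.

Diethylamino differs from the group it replaces in heavy atoms, ring content and hydrogen-bond acceptors all at once, and the compounds shown do not separate these counts. Also open, going by these compounds, is how the read-out would respond at this position to a smaller amine such as dimethylamino, to a single-ring amine such as morpholine, or to a longer chain carrying the same diethylamino, and whether the change would hold with other parts of the core altered.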